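Swapping Acetamido for Fluoro on a Shared Core

A few compounds are considered here, and "the series" means these few. Any claim that something is new, unique, unknown or untested is made for them only; others in the source may bear on it.

Two compounds share one core. Compound 1 `COc1ccccc1NC(=O)c1ccccc1Sc1ccc([N+](=O)[O-])cc1` carries no extra group on the ring that bears the (4-nitrophenyl)sulfanyl group, and in an ADME assay on H9 cells (Homo sapiens) for cytotoxicity, read by MTT assay, with a stated time of 7 days (a lower number here means that less compound is tolerated, a higher number that more compound is tolerated), compound 1 gives "not determined" (no result reported). Among the compounds with values here, compound 2 `COc1ccccc1NC(=O)c1cc(NC(C)=O)ccc1Sc1ccc([N+](=O)[O-])cc1` carries an acetamido group there; in this assay compound 2 gives 171000 nM, the only number known in this assay, so compound 2 stands alone as the single reference point. Compound 3 `COc1ccccc1NC(=O)c1cc(F)ccc1Sc1ccc([N+](=O)[O-])cc1` differs from compound 2 in one place: fluoro in place of acetamido on an aromatic carbon. Within the data shown here, no measured pair shows how such a swap moves this assay, so no step size is known from the data. With a lone reference, the expected step is small, possibly within the scatter, and is estimated as a 1.4-fold lower number from compound 2 to compound 3 (0.15 log units; within the scatter). For compound 3 the estimate in this assay is 120000 nM, with an expected range from 40000 nM to 300000 nM.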

Compound 3, half-maximal cytotoxic concentration: 502000 nM
Compound 3: middle estimate off by 4.2-fold (0.62 log units), on the low side; measured number above the stated range.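

In this assay, the position para to the (4-nitrophenyl)sulfanyl group now has its first readable step: fluoro in place of acetamido gives a 2.9-fold higher number from compound 2 to compound 3 (0.47 log units; beyond the scatter), so more compound is tolerated with fluoro there. This shows that the group at this position can shift the read-out by more than the usual scatter, although that rests on this single pair. Nothing shown explains why the number rises with this swap.

From the compounds shown here alone, for compound 1, which has no extra group at this position, the entry reads "not determined" (no result reported), so steps to it cannot be read and it stays open whether acetamido, fluoro or both move the number away from the unsubstituted core. Going by these compounds, how an amine, a carboxylic acid or a longer chain at this position would behave also stays open.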